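The source may hold more compounds than are shown below. What is called first, only, known or untested is meant among the compounds shown, and "the series" means these compounds.

Measured compounds:
compound 1 `N#CC1=C(NC(=O)C2CC2)N(c2ccc(S(N)(=O)=O)cc2)C2=C(C(=O)CCC2)C1c1ccc(Cl)cc1Cl` — 20%
compound 2 `NC(=O)C1=C(N)N(c2ccc(S(N)(=O)=O)cc2)C2=C(C(=O)CCC2)C1c1ccc(Cl)cc1Cl` — 30%

In a functional assay on Ehrlich cells (Mus musculus) for cytotoxicity, read by trypan blue exclusion, with a stated time of 2 h, tested at 10 ug/mL (a lower number here means a weaker effect, a higher number a stronger effect of the compound at the concentration tested), compound 1 gives 20%, the lowest of the two numbers. Compound 2 gives 30% in the same test, a value that lies within the usual scatter of repeated measurements of the first, so the two compounds cannot be told apart on these numbers. Going by the values given here, no step between the measured compounds is available, and both belong to the same shared core.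

Compound 3 `CN(C)c1ccc(/C=N/C2=C(C#N)C(c3ccc(Cl)cc3Cl)C3=C(CCCC3=O)N2c2ccc(S(N)(=O)=O)cc2)cc1` has not been measured in this assay. It differs from compound 1 in one place: a group of 11 heavy atoms (9 carbon, 2 nitrogen; one six-membered aromatic ring of carbon only) in place of a group of 6 heavy atoms (4 carbon, 1 nitrogen, 1 oxygen; one three-membered non-aromatic ring of carbon only), on a double-bonded ring carbon. Among the compounds with values here, there is no measured pair that shows what such a replacement on a double-bonded ring carbon does in this assay, so the only guide is the level of the two known values, which sit close together.

Compound 3 is therefore expected to stay near compound 1, with a step from compound 1 to compound 3 of a number 5 percentage points higher from compound 1 to compound 3 (within the scatter), nothing beyond the scatter in either direction. The estimate for compound 3 in this assay is 25%, within a range from 10% to 45%.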

Compound 3, a percentage reported as activity, at one concentration (the size of the read-out at that concentration, not a potency): 10%
Beside the measured number, compound 3's estimate is 15 percentage points above it; low and high end bracket the measured number.
By their numbers in this assay, from the lowest: compounds 3, 1 and 2 (each within the scatter of the next, the first and the last beyond it).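

In this assay, putting the group of 11 heavy atoms with its six-membered aromatic ring of carbon only in place of (cyclopropylcarbonyl)amino, on the double-bonded ring carbon, gives a number 10 percentage points lower from compound 1 to compound 3 (within the scatter). Going by these compounds alone, this is the first step measured at this position, and it shows that a change of this size, which removes the three-membered ring and leaves no hydrogen-bond donor in the entering group, does not move the read-out beyond the usual scatter. Nothing measured here explains the outcome of this change, and with this one step it cannot be said which part of the entering group matters, if any does.

As far as these compounds go, whether a morpholine or a longer alkyl chain on this double-bonded ring carbon would take the read-out beyond the scatter of compound 1 remains open. Also open is what a carboxylic acid would do in place of the cyano group while the rest of compound 1 stays the same, since no single change at that place is shown here.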